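The source may report more compounds than this note shows. Statements on the series, on what has been measured and on what is new or still open speak of the compounds shown alone.

Among the compounds with values here, compound 3 `CN(c1ncccc1CNc1nc(Nc2ccc3c(c2)CC(=O)N3)nc2[nH]cc(F)c12)S(C)(=O)=O` sits at the top of the two numbers so far in a functional assay on SMMC-7721 cells (Homo sapiens) for inhibition, read by MTT assay, with a stated time of 48 h (a lower number here means a stronger inhibitor, a higher number a weaker inhibitor), giving 73200 nM. Its nearest neighbour is compound 1 `Cc1c[nH]c2nc(Nc3ccc4c(c3)CC(=O)N4)nc(NCc3cccnc3N(C)S(C)(=O)=O)c12`, which gives 18700 nM; the step of a 3.9-fold higher number from compound 1 to compound 3 (0.59 log units; beyond the scatter) rests on a change on the core carbon only. Compound 2 `Cc1cc2c(NCc3cccnc3N(C)S(C)(=O)=O)nc(Nc3ccc4c(c3)CC(=O)N4)nc2[nH]1` is reported only as a limit, > 100000 nM, and not as a number (the limit of > 100000 nM in this assay, at which 1 of the 3 values shown sits).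

Compound 4 `COc1ccc(Nc2nc(NCc3cccnc3N(C)S(C)(=O)=O)c3c(F)c[nH]c3n2)cc1OC` differs from compound 3 at the aromatic amine instead: a group of 10 heavy atoms (8 carbon, 2 oxygen; one six-membered aromatic ring of carbon only) in place of a group of 10 heavy atoms (8 carbon, 1 nitrogen, 1 oxygen; one five-membered non-aromatic ring with 1 hetero atom, one six-membered aromatic ring of carbon only), on a nitrogen on an aromatic ring. Within the data shown here, no measured step covers this position, so the expectation for compound 4 rests on its parent alone. Compound 4 is therefore expected to show a 1.1-fold higher number from compound 3 to compound 4 (0.04 log units; within the scatter), a step of no clear direction; compound 4 is estimated at 80000 nM, within 15000 nM to 300000 nM.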

Compound 4, half-maximal inhibitory concentration: 54800 nM
For compound 4 the middle estimate is 1.5-fold (0.16 log units) above the measured one, and the stated range covers the measured number.
By their numbers in this assay, from the lowest: compound 1; then compounds 4 and 3 (each within the scatter of the next). At a limit, above all of these: compound 2.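

Within the data shown here, on the nitrogen on an aromatic ring, 3,4-dimethoxyphenyl replaces the two-ring group of compound 3 in this assay with a 1.3-fold lower number from compound 3 to compound 4 (0.13 log units; within the scatter) as the first reading at this position. The exchange therefore gives no change beyond the scatter on the fluoro-bearing core, although the hydrogen-bond donor of the leaving group is absent from the entering one. Nothing measured here bears on why these two values stay so close.

Open, from the compounds shown here alone, is whether an amine or a carboxylic acid on the phenyl ring would move the number. Also open, going by these compounds, is whether 3,4-dimethoxyphenyl reads the same with methyl in place of fluoro on the core.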